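Purine nucleoside series: shortening the chain substituent on the aromatic nitrogen

This account rests on a few compounds, and the source may have more. Where it says the series, first, only, none or still open, it means among the compounds named here.

Of the compounds shown here, three have been measured in a functional assay on the whole organism (B cells) with Mus musculus as the target; a higher number here means a larger maximal response, a lower number a smaller maximal response. Compound 1 `CC1OC(n2c(=O)n(C)c3c(O)nc(N)nc32)[C@H](O)[C@@H]1O` gives 0%. Compound 2 `Nc1nc(O)c2c(n1)n(C1OC(CO)[C@@H](O)[C@H]1O)c(=O)n2CC(O)CSc1ccccc1` gives 12%, the second highest of the three numbers; it lies beyond the usual scatter above compound 1, while compound 3 `CC1(C)O[C@@H]2[C@H](O1)[C@@H](CO)O[C@H]2n1c(=O)n(C/C=C/c2ccccc2)c2c(O)nc(N)nc21`, which gives 16%, sits within the scatter of compound 2, so no order between compound 2 and compound 3 can be read from these numbers.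

Compound 4 `CCn1c(=O)n(C2OC(CO)[C@@H](O)[C@H]2O)c2nc(N)nc(O)c21` has not yet been measured. It differs from compound 2 in one place: methyl in place of 1-hydroxy-2-(phenylsulfanyl)ethyl on a saturated chain carbon bound to an aromatic nitrogen. Within the data shown here, no measured pair differs in exactly one place, so no step can be quoted directly. The step from compound 2 to compound 4 is expected to go down, by an amount around the edge of the scatter, because compound 1 with a methyl on this nitrogen gives 0% in this assay. The expected step is a number 8 percentage points lower from compound 2 to compound 4 (within the scatter). Compound 4 is therefore estimated at 4% in this assay, with a range from 0% to 14%.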

Compound 4, largest response reached (reported as maximal response), in percent of the reference or control that the assay uses: 82%
The estimate for compound 4 lay 78 percentage points below the measured number; the whole stated range lies below it.
By their numbers in this assay, from the lowest: compound 1; then compounds 2 and 3 (each within the scatter of the next); then compound 4.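

Among these compounds, on a saturated chain carbon bound to an aromatic nitrogen, the exchange of 1-hydroxy-2-(phenylsulfanyl)ethyl for methyl gives a number 70 percentage points higher from compound 2 to compound 4 (beyond the scatter) in this assay, the first step that can be read directly. This place therefore has a strong hold on the maximal response in this pair, and the small methyl, with no ring and no hydrogen-bond donor or acceptor, goes with the far higher number. Nothing available explains why the step is so large.

The departing group changes its hydroxyl, sulfur and phenyl ring all at once, so the pair cannot show which of them matters. As far as these compounds go, how a propyl chain or a short chain ending in an amine would fare at this place remains open, and so does whether the response falls gradually or abruptly as the chain grows.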